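The compounds below may be only part of what the source reports. "The series", "measured", "known", "first", "only" and "open" are said of these compounds alone.

Of the compounds shown here, three sharing one core have been tested in a functional assay (aorta) with Rattus norvegicus as the target; on this read-out lower numbers stand for stronger inhibition and higher numbers for weaker inhibition. Compound 1 (`CC(C)c1cn2ccccc2c1S(=O)(=O)c1ccc(OCCCNCc2ccccc2)cc1`) gives 22.8 nM, and compound 2 (`CCCCN(CCCC)CCCCOc1ccc(S(=O)(=O)c2c(C(C)C)cn3ccccc23)cc1`) gives 20.2 nM. The gap between these two is a 1.1-fold lower number from compound 1 to compound 2 (0.05 log units; within the scatter). Compound 3 (`CC(C)c1cn2ccccc2c1S(=O)(=O)c1ccc(OCCCN(C)C)cc1`) gives 390 nM, the highest number of the three, which makes it the weakest inhibitor so far.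

Compound 4 (`CCCCN(CCCC)CCCOc1ccc(S(=O)(=O)c2c(C(C)C)cn3ccccc23)cc1`) has not yet been measured, and it differs from compound 3 by a single change: dibutylamino in place of dimethylamino on a saturated chain carbon, three bonds along the chain from an oxygen on an aromatic ring. The nearest measured step is a 19-fold higher number from compound 2 to compound 3 (1.29 log units; beyond the scatter), although that step also alters the chain. The other is a 17-fold higher number from compound 1 to compound 3 (1.23 log units; beyond the scatter), which keeps the chain unchanged. Both steps are large and both rise to compound 3, so a large step to a lower number is expected in this assay when dibutylamino enters. The expected size is a 13-fold lower number from compound 3 to compound 4 (1.11 log units; beyond the scatter). The estimated value for compound 4 is 30 nM, with an expected range of 10 nM to 90 nM.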

Compound 4, half-maximal inhibitory concentration: 21.6 nM
The estimate for compound 4 lay 1.4-fold (0.14 log units) above the measured number; low and high end bracket the measured number.
By their numbers in this assay, from the lowest: compounds 2, 4 and 1 (each within the scatter of the next); then compound 3.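

Compound 4 separates the amine from the chain: with the chain held as in compound 3, dibutylamino in place of dimethylamino gives an 18-fold lower number from compound 3 to compound 4 (1.26 log units; beyond the scatter) in this assay, so the large gap seen earlier does not need the longer chain of compound 2. Lengthening the chain with dibutylamino kept in place gives only a 1.1-fold higher number from compound 2 to compound 4 (0.03 log units; within the scatter) and so shows no change that can be told from scatter. Dibutylamino and the benzylamino of compound 1 also cannot be told apart, with a 1.1-fold lower number from compound 1 to compound 4 (0.02 log units; within the scatter) on the same chain, which leaves dimethylamino as the only one of these amines with a clearly higher number.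

As far as these compounds go, whether diethylamino, or a ring amine such as piperidine, would behave like dimethylamino or like dibutylamino remains open. Nothing given here bears on why these amines differ.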